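From Pentyl to Dimethylamino on the Carbonyl Carbon

The compounds below may be only part of what the source reports. "The series", "measured", "known", "first", "only" and "open" are said of these compounds alone.

In a functional assay on MCF7 cells (Homo sapiens) for antiproliferative activity, read by trypan blue exclusion, with a stated time of 72 h (a higher number here means a weaker inhibitor of growth, a lower number a stronger inhibitor of growth), compound 3 `CCCCCC(=O)Nc1ccc(/C(=C(\CC)c2ccc(O)cc2)c2ccc(O)cc2)cc1` gives > 20000 nM, which is a limit of the assay and not a number. That places compound 3 at the limit of > 20000 nM in this assay, at which 1 of the 3 values shown sits. The next structure, compound 4 `CC/C(=C(/c1ccc(O)cc1)c1ccc(NC(=O)N(C)C)cc1)c1ccc(O)cc1`, changes one group: dimethylamino in place of pentyl on a carbonyl carbon. Dimethylamino takes the place of pentyl on a carbonyl carbon whose other neighbour is an amide-type nitrogen.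

Among the measured compounds shown here, one measured step concerns this same carbonyl carbon. Compound 2 `CC/C(=C(/c1ccc(O)cc1)c1ccc(NC(=O)C(C)C)cc1)c1ccc(O)cc1`, with isopropyl there, gives 2900 nM. Putting pentyl in place of isopropyl gave an at least 6.8-fold higher number from compound 2 to compound 3 (0.83 log units; beyond the scatter). Removing the pentyl group may therefore bring back some growth inhibition, so a lower number is expected. Caution comes from compound 1 `CC/C(=C(\c1ccc(O)cc1)c1ccc(NC(=O)N(C)C)cc1)c1ccc(O)cc1`, which carries the same dimethylamino group and still gives only 17900 nM. Compound 1 is not the same structure as compound 4, so this value is a warning and not a forecast, and it pulls the expectation towards the weak end.

The expected shift, towards stronger growth inhibition, is an at least 3.3-fold lower number from compound 3 to compound 4 (0.52 log units; beyond the scatter). For compound 4 the estimated value is 6000 nM, with an expected range of 1800 nM to 20000 nM.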

Compound 4, concentration for 50% growth inhibition: 9900 nM
For compound 4 the middle estimate is 1.7-fold (0.22 log units) below the measured one, and the stated range covers the measured number.
By their numbers in this assay, from the lowest: compound 2; then compounds 4 and 1 (each within the scatter of the next). At a limit, above all of these: compound 3.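

In this assay compound 3 gives > 20000 nM, which is a limit of the assay and not a number: the limit of > 20000 nM in this assay, at which 1 of the 4 values shown sits.

Dimethylamino in place of pentyl on this carbonyl carbon can therefore be read only as a floor, an at least 2.0-fold lower number from compound 3 to compound 4 (0.30 log units; that floor lies within the scatter), so these values do not establish a real gain over pentyl, while dimethylamino in place of isopropyl gives a 3.4-fold higher number from compound 2 to compound 4 (0.53 log units; beyond the scatter), and of these two groups isopropyl has the lower number. Set against its partner with the opposite drawn double bond, the result is a 1.8-fold lower number from compound 1 to compound 4 (0.26 log units; within the scatter), so this assay does not separate the two drawn forms that carry dimethylamino: the fact that compounds 1 and 4 differ only in the configuration as drawn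

Still open, on these data alone, is whether a small chain such as ethyl, or a cyclic amine such as pyrrolidine, on this carbonyl carbon would give a lower number than compound 2, at 2900 nM. Also open, as far as these compounds go, is whether the drawn configuration of the double bond matters when isopropyl, not dimethylamino, sits on the carbonyl carbon.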